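The compounds below may be only part of what the source reports. "The series", "measured", "known", "first", "only" and "open" are said of these compounds alone.

Among the measured compounds shown here, compound 2 `COC(=O)c1cc(N)c(Nc2ccc(C#N)cc2)cc1Oc1c(C)cc(/C=C/C#N)cc1C` gives 1.75 ug/mL in a physicochemical assay for solubility, with a stated time of 4 h, at pH 2.0; a higher number here means a more soluble compound, a lower number a less soluble compound; compound 1 `Cc1cc(/C=C/C#N)cc(C)c1Oc1cc(Nc2ccc(C#N)cc2)c(N)cc1C(N)=O`, the only other measured compound, gives 2.09 ug/mL in this assay, and the two stand within the scatter of each other. For the measured compounds named here, the single measured step, a 1.2-fold lower number from compound 1 to compound 2 (0.08 log units; within the scatter), puts methoxy in place of amino on a carbonyl carbon. Compound 3 `CNC(=O)c1cc(N)c(Nc2ccc(C#N)cc2)cc1Oc1c(C)cc(/C=C/C#N)cc1C` differs from compound 2 by methylamino in place of methoxy on a carbonyl carbon. Since that one step at the same carbonyl carbon stayed within the scatter, no step beyond the scatter is expected here either. Compound 3 is therefore expected to give 2 ug/mL in this assay, with a range from 0.8 ug/mL to 5 ug/mL. The expected step is a 1.1-fold higher number from compound 2 to compound 3 (0.06 log units; within the scatter).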

Compound 3, solubility: 8.63 ug/mL
Beside the measured number, compound 3's estimate is 4.3-fold (0.63 log units) below it; the whole stated range lies below it.
By their numbers in this assay, from the lowest: compounds 2 and 1 (each within the scatter of the next); then compound 3.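

At this carbonyl carbon the choice of group can move the number in this assay: the earlier swap stayed within the scatter, but methylamino in place of methoxy brings a 4.9-fold higher number from compound 2 to compound 3 (0.69 log units; beyond the scatter). Methyl in place of hydrogen on the amide-type nitrogen brings a 4.1-fold higher number from compound 1 to compound 3 (0.62 log units; beyond the scatter), so compound 3 stands apart from both the primary amide and the ester. Nothing measured here accounts for this step. On these data alone, whether ethylamino, dimethylamino or a carboxylic acid on this carbonyl carbon would give a number nearer compound 3 or nearer compound 2 stays open.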